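The compounds below may be only part of what the source reports. "The series", "measured", "known", "first", "only" and "open" are said of these compounds alone.

Working notes on the series. In a functional assay on HCT-116 cells (Homo sapiens) for antiproliferative activity, read by sulforhodamine B assay, with a stated time of 72 h (on this read-out lower numbers stand for stronger inhibition of growth and higher numbers for weaker inhibition of growth), compound 1 (`N=C1NC(=O)/C(=C/c2ccc(-c3ccccc3[N+](=O)[O-])o2)S1`) gives > 80000 nM, which is a limit and not a number. Compound 2 (`N=C1NC(=O)/C(=C/c2ccc(-c3ccc(S(=O)(=O)N4CCNCC4)cc3)o2)S1`) gives > 80000 nM, also a limit. Among the compounds with values here, compound 2 therefore has no numerical position, and the only guide is the limit of > 80000 nM in this assay, at which 2 of the 2 values shown sit.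

Compound 3 (`N=C1NC(=O)/C(=C/c2ccc(-c3ccc(C(N)=O)cc3)o2)S1`) has carbamoyl in place of (piperazin-1-yl)sulfonyl on an aromatic carbon, para to a large group: carbamoyl in place of (piperazin-1-yl)sulfonyl on an aromatic carbon. Within the data shown here, no measured step between compounds that differ in one place is available to size this change. The expected change, an at least 1.3-fold lower number from compound 2 to compound 3 (0.12 log units; that floor lies within the scatter), is small and, if it can be seen at all, toward stronger inhibition of growth. A further limit in this assay would be no surprise. For compound 3 the estimated value is 60000 nM, with an expected range of 20000 nM to 80000 nM.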

Compound 3, concentration for 50% growth inhibition: > 80000 nM
Compound 3 ended at the assay's limit (the forecaster's own chance of this, stated with the estimate: 65%); middle value at least 1.3-fold (0.12 log units) from the limit.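

Compound 2 and compound 3 both sit at a limit and not at a number, so no step can be read for carbamoyl in place of (piperazin-1-yl)sulfonyl in this assay. The compounds shown leave open which change on the shared core would give a measurable value, as all remain at one limit: the limit of > 80000 nM in this assay, at which 3 of the 3 values shown sit.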